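This account rests on a few compounds, and the source may have more. Where it says the series, first, only, none or still open, it means among the compounds named here.

Measured in a functional assay on SW-620 cells (Homo sapiens) for cytotoxicity, read by MTT assay, with a stated time of 72 h; a lower number here means a stronger inhibitor, a higher number a weaker inhibitor:
- compound 1 `COc1cccc(/C=C2\CCC/C(=C\c3ccc(Cl)cc3)C2=O)c1OC`: 11100 nM
- compound 2 `COc1cccc(/C=C2\CCC/C(=C\c3cccc(O)c3)C2=O)c1OC`: 6400 nM

Among the compounds with values here, on these numbers, compound 2 cannot be separated from compound 1, its only measured neighbour. Next comes compound 3 `COc1cccc(/C=C2\CCC/C(=C\c3ccc(O)cc3)C2=O)c1OC`, with 4-hydroxyphenyl in place of 3-hydroxyphenyl on a double-bonded chain carbon bound to a double-bonded ring carbon. Within the data shown here, the only measured step, a 1.7-fold lower number from compound 1 to compound 2 (0.24 log units; within the scatter), changed the group at this same place and stayed within the scatter. Among the measured compounds shown here, no measured pair shows this exact swap, so no change beyond the scatter is expected in this assay. The expected step is a 1.0-fold higher number from compound 2 to compound 3 (0.01 log units; within the scatter). For compound 3 the estimate is 6500 nM, with a range of 2700 nM to 14000 nM.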

Compound 3, half-maximal inhibitory concentration: > 20000 nM
Compound 3 ended at the assay's limit; the forecaster's own chance of this, stated with the estimate: 5%; at least 3.0-fold (0.48 log units) between middle value and limit.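

In this assay, compound 3 sits at a limit of the assay rather than at a number: the limit of > 20000 nM in this assay, at which 1 of the 3 values shown sits. Changing 3-hydroxyphenyl to 4-hydroxyphenyl, with the same atoms joined differently, gives an at least 3.1-fold higher number from compound 2 to compound 3 (0.49 log units; beyond the scatter), so this place responds to where the hydroxy stands, which the earlier pair could not show. Hydroxy in place of chloro on an aromatic carbon gives an at least 1.8-fold higher number from compound 1 to compound 3 (0.25 log units; that floor lies within the scatter), so the size of that swap stays unsettled.

Going by these compounds, how far compound 3 lies past the limit remains open. So does whether an amine or a carboxylic acid in place of the hydroxy would show the same dependence on where it stands.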